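Dropping an Isopropyl Group from a Low-Toxicity Compound

A few compounds are considered here, and "the series" means these few. Any claim that something is new, unique, unknown or untested is made for them only; others in the source may bear on it.

Compound 2 `COc1ccc([C@H](C)N(Cc2ccc(C(C)(C)C)cc2)Cc2cc3cc(C(C)C)ccc3[nH]c2=O)cc1` was examined in a toxicity assay on MDCK cells (Canis lupus familiaris) for cytotoxicity, read by crystal violet staining, with a stated time of 48 h; on this read-out higher numbers stand for lower toxicity in this test and lower numbers for higher toxicity in this test. In this assay compound 2 gives > 10000 nM, which is a limit of the assay rather than a measured number. Its closest measured neighbour is compound 1 `CCc1ccc2[nH]c(=O)c(CN(Cc3ccc(C(C)(C)C)cc3)[C@@H](C)c3ccc(OC)cc3)cc2c1`, which carries a methyl in place of hydrogen on a saturated chain carbon bound to an aromatic carbon and a saturated chain carbon. In this assay compound 1 gives > 5000 nM, again a limit. The step that the two limits leave unreadable from compound 1 to compound 2 is therefore unreadable in size because the limit of > 10000 nM in this assay, at which 1 of the 2 values shown sits, and the limit of > 5000 nM in this assay, at which 1 of the 2 values shown sits, mark both ends.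

Compound 3 `COc1ccc([C@H](C)N(Cc2ccc(C(C)(C)C)cc2)Cc2cc3ccccc3[nH]c2=O)cc1` differs from compound 2 by hydrogen in place of isopropyl on an aromatic carbon. For the measured compounds named here, no measured step in this small set bears directly on that change, and the only step available, from compound 1 to compound 2, yields no readable size. Both measured compounds show no detectable toxicity up to their limits. Compound 3 is therefore expected to remain near the limit, and the step that the limit leaves unreadable from compound 2 to compound 3 is expected to stay within the scatter. Compound 3 is estimated at 15000 nM, with a range from 5000 nM to 50000 nM.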

Compound 3, half-maximal cytotoxic concentration: 1800 nM
Compound 3: the middle estimate sits 8.3-fold (0.92 log units) above what was measured; the whole stated range lies above it.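

For the compounds shown here, with compound 3, this assay gives a readable number for the first time in this set, and it shows that the alkyl group on this aromatic carbon matters to the read-out: replacing isopropyl with hydrogen gives an at least 5.5-fold lower number from compound 2 to compound 3 (0.74 log units; beyond the scatter). Replacing ethyl with hydrogen at the same carbon points the same way, with an at least 2.7-fold lower number from compound 1 to compound 3 (0.44 log units; beyond the scatter), so both alkyl compounds stand apart from the unsubstituted one, with lower toxicity in this test. Both steps are minimum sizes, and the first is one because compound 2 rests on a limit of the assay: the limit of > 10000 nM in this assay, at which 1 of the 3 values shown sits.

The step between the ethyl and isopropyl compounds cannot be read, so the compounds shown do not tell whether the size of the alkyl group matters once one is present, or how much toxicity either group removes in full. They also leave open whether the low toxicity depends on an alkyl group as such, or whether a methoxy group, an amine, a carboxylic acid or a longer chain on this aromatic carbon would hold the number away from that of compound 3.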